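Shared core, HT-29 growth inhibition: the step to compound 4

This account rests on a few compounds, and the source may have more. Where it says the series, first, only, none or still open, it means among the compounds named here.

The series keeps one shared core and varies the aryl group on the amide-type nitrogen. Compound 1 `COc1ccc(C)cc1NC(=S)N/N=C/c1ccc2ccccc2n1` reaches only a limit in a functional assay on HT-29 cells (Homo sapiens) for antiproliferative activity, read by sulforhodamine B assay, with a stated time of 72 h (on this read-out lower numbers stand for stronger inhibition and higher numbers for weaker inhibition), giving > 100000 nM (the limit of > 100000 nM in this assay, at which 1 of the 3 values shown sits). Compound 2 `Fc1cccc(NC(=S)N/N=C/c2ccc3ccccc3n2)c1` gives 74700 nM in this assay, and compound 3 `S=C(N/N=C/c1ccc2ccccc2n1)Nc1cccc(Cl)c1` gives 48100 nM. For the measured compounds named here, the only measured step, a 1.6-fold lower number from compound 2 to compound 3 (0.19 log units; within the scatter), stays within the scatter, so compound 3 shows the lower of the two numbers without any order being claimed between them.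

Compound 4 `Cc1ccccc1NC(=S)N/N=C/c1ccc2ccccc2n1` is not yet measured. The change from compound 3 is 2-methylphenyl in place of 3-chlorophenyl on an amide-type nitrogen. Going by the values given here, no measured step bears directly on this exchange: a 1.6-fold lower number from compound 2 to compound 3 (0.19 log units; within the scatter) concerned chloro against fluoro only, and compound 1, the one other substituted aryl, reached only a limit. Among the compounds with values here, all numbers so far sit high and no step beyond the scatter has appeared, so for compound 4 a number near that of compound 3 or somewhat higher is expected, with a real chance of a limit. The estimated step is a 1.7-fold higher number from compound 3 to compound 4 (0.22 log units; within the scatter). The estimate for compound 4 is 80000 nM, with a range from 35000 nM to 200000 nM.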

Compound 4, half-maximal inhibitory concentration: 42300 nM
Estimate against measurement, compound 4: 1.9-fold (0.28 log units) above; the range from low to high includes it.
By their numbers in this assay, from the lowest: compounds 4, 3 and 2 (each within the scatter of the next). At a limit, above all of these: compound 1.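

The exchange of 3-chlorophenyl for 2-methylphenyl on the amide-type nitrogen gives a 1.1-fold lower number from compound 3 to compound 4 (0.06 log units; within the scatter), and the exchange of 3-fluorophenyl for 2-methylphenyl gives a 1.8-fold lower number from compound 2 to compound 4 (0.25 log units; within the scatter). For the compounds shown here, until now, the only readable step at this position was one halogen against another; in this assay, an aryl group bearing a methyl group now also falls within the scatter of both halogen-bearing compounds, so no order can be drawn among the three. Compound 1 remains a limit and offers no readable step: the limit of > 100000 nM in this assay, at which 1 of the 4 values shown sits.

From the compounds shown here alone, no step beyond the scatter has yet appeared among the measured numbers, so how far this position can move the read-out remains open. Also open, going by these compounds, is whether an aryl group carrying an amine or a carboxylic acid, or a longer chain in place of the aryl group, would give such a step.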